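This account rests on a few compounds, and the source may have more. Where it says the series, first, only, none or still open, it means among the compounds named here.

Measured compounds in a functional assay on HO8910 cells (Homo sapiens) for cytotoxicity, read by CCK-8 assay, with a stated time of 24 h; a lower number here means a stronger inhibitor, a higher number a weaker inhibitor:

compound 1 `C/C(=C\c1cc(-c2ccc(C)cc2)co1)C(N)=O`; in this assay compound 1 gives 24200 nM.
compound 2 `C/C(=C\c1cc(-c2ccc(F)cc2)co1)C(N)=O`; in this assay compound 2 gives > 50000 nM, which is a limit of the assay rather than a number.
compound 3 `C/C(=C\c1nc(-c2ccc(C)cc2)cs1)C(N)=O`; in this assay compound 3 gives > 50000 nM, again a limit of the assay rather than a number.

Compound 1 and compound 2 share one core and differ in a single place, (fluoro in place of methyl on an aromatic carbon). The step is an at least 2.0-fold higher number from compound 1 to compound 2 (0.31 log units; beyond the scatter); only its lower bound is known, because the value of compound 2 sits at the limit of > 50000 nM in this assay, at which 2 of the 3 values shown sit.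

Compound 3 carries a different core. The difference between the core of compound 1 and the core of compound 3 is not broken down here; what can be said is that compound 1 gives a number and compound 3 gives only a limit.

Compound 4 `C/C(=C\c1nc(-c2ccc(F)cc2)cs1)C(N)=O` is not yet measured in this assay. Going by the values given here, it differs from compound 3 by fluoro in place of methyl on an aromatic carbon, the same change, at the same kind of place, as the one from compound 1 to compound 2.

Among the compounds with values here, for compound 4 the step expected is a step that the limit leaves unreadable from compound 3 to compound 4, resting on the one measured instance of this change, an at least 2.0-fold higher number from compound 1 to compound 2 (0.31 log units; beyond the scatter), which did not lower the number, and on compound 3 already standing at the limit. Compound 4 is therefore estimated at 100000 nM, with a range from 50000 nM to 300000 nM, and the assay is expected most likely to report only a limit for compound 4.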

Compound 4, half-maximal inhibitory concentration: 4450 nM
For compound 4 the middle estimate is 22-fold (1.35 log units) above the measured one, outside the stated range (below it).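

In this assay, fluoro in place of methyl on an aromatic carbon of the six-membered aromatic ring gives an at least 11-fold lower number from compound 3 to compound 4 (1.05 log units; beyond the scatter), a large gain on the core of compound 3. This change therefore does not carry over from one core to the other in this series, not even in direction, and a result on one core gives no safe forecast for the other: the same change on two cores in this assay, an at least 2.0-fold higher number (0.31 log units; beyond the scatter) from compound 1 to compound 2 and an at least 11-fold lower number (1.05 log units; beyond the scatter) from compound 3 to compound 4, at least 23-fold (1.36 log units) apart, beyond the scatter of two such steps

The two cores supply only one pair each, and both steps are known only as bounds, so the data show neither the full size of either step nor which feature of the cores separates them, and they set no rule for any further core: the limit of > 50000 nM in this assay, at which 2 of the 4 values shown sit.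

The compounds shown leave open how other groups at the same place, such as chloro, methoxy or trifluoromethyl, would behave on each core, and so whether fluoro stands alone or belongs to a wider trend on the core of compound 3. They also leave open whether the opposite outcomes on the two cores would persist with a carboxylic acid or a nitrile in place of the primary amide.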